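This account rests on a few compounds, and the source may have more. Where it says the series, first, only, none or still open, it means among the compounds named here.

Measured so far in a functional assay on HEp-2 cells (Homo sapiens) for cytotoxicity, read by MTT assay; on this read-out higher numbers stand for weaker inhibition and lower numbers for stronger inhibition:
- compound 1, `CC1=NNC(=O)C1C(c1c(-c2ccccc2)[nH]c2ccc(C)cc12)c1c(-c2ccccc2)[nH]c2ccc(C)cc12`: > 100000 nM.
- compound 2, `CC1=NNC(=O)C1C(c1c(-c2ccccc2)[nH]c2ccccc12)c1c(-c2ccccc2)[nH]c2ccc(C)cc12`: > 100000 nM.
- compound 3, `CC1=NNC(=O)C1C(c1c(-c2ccccc2)[nH]c2ccc(Cl)cc12)c1c(-c2ccccc2)[nH]c2ccc(Cl)cc12`: 14600 nM.

For compound 1 the value in this assay is a limit of the assay, not a number. For compound 2 the value in this assay is likewise a limit. Compound 3 is the only one of the three with a number; the two other values sit at the limit of > 100000 nM in this assay, at which 2 of the 3 values shown sit. Among the compounds with values here, the one step between measured compounds, a step that the two limits leave unreadable from compound 1 to compound 2, cannot be read because both ends are limits.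

Compound 4, `CC1=NNC(=O)C1C(c1c(-c2ccccc2)[nH]c2ccccc12)c1c(-c2ccccc2)[nH]c2ccc(Cl)cc12`, differs from compound 3 by hydrogen in place of chloro on an aromatic carbon, on an aromatic carbon of a six-membered aromatic ring of carbon only, part of a fused or bridged system of two rings. Within the data shown here, no measured step bears on this change: the methyl-for-hydrogen step from compound 1 to compound 2 is unreadable, and no chloro-to-hydrogen pair has been measured. Among the measured compounds shown here, the only guide is that the dichloro compound 3 carries the sole number while the methyl compounds sit at a limit; removing one chloro is therefore expected to move compound 4 toward weaker inhibition by a 2.7-fold higher number from compound 3 to compound 4 (0.44 log units; beyond the scatter), with a real chance of a limit. Compound 4 is estimated at 40000 nM, range 12000 nM to 120000 nM.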

Compound 4, half-maximal inhibitory concentration: 41700 nM
Compound 4: the middle estimate sits 1.0-fold (0.02 log units) below what was measured; measured number inside the range.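

In this assay, within the data shown here, the chloro on the aromatic carbon meta to a fused ring and para to a fused ring gives the first readable step: a 2.9-fold higher number from compound 3 to compound 4 (0.46 log units; beyond the scatter) on its replacement by hydrogen, so the second chloro still counts when one chloro remains. With the other half of the core unchanged, the change at this place gives an at least 2.3-fold lower number from compound 2 to compound 4 (0.37 log units; beyond the scatter) for chloro in place of methyl, which ranks chloro ahead of methyl here. Only a bound on that step can be read, as compound 2 is a limit: the limit of > 100000 nM in this assay, at which 2 of the 4 values shown sit.

From the compounds shown here alone, how a fluoro, a bromo, a methoxy or an amine at this place would compare with chloro remains open. So does whether the chloro step holds when the phenyl groups on the core carry other substituents.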